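The source may report more compounds than this note shows. Statements on the series, on what has been measured and on what is new or still open speak of the compounds shown alone.

Measured compounds:
compound 1 `CC(C)N1CCN(Cc2csc(N)c2C(=O)c2ccc(Cl)cc2)CC1` with 7.3% in a functional assay on CHO cells with adenosine receptor A1 (Homo sapiens) as the target, read by cAMP accumulation and immunoassay, with a stated time of 6 min, tested at 1 uM; on this read-out lower numbers stand for a stronger effect and higher numbers for a weaker effect at the one concentration tested
compound 2 `Nc1scc(CN2CCN(c3ccccc3F)CC2)c1C(=O)c1ccc(Cl)cc1` with -9.2% in this assay

Compound 2 stands lowest of the two numbers; its nearest neighbour is compound 1, and the step of a number 16.5 percentage points lower from compound 1 to compound 2 (beyond the scatter) lies beyond the scatter. Compound 3 `Nc1scc(CN2CCN(c3ccc(F)c(F)c3)CC2)c1C(=O)c1ccc(Cl)cc1` has not yet been measured in this assay. It differs from compound 2 by 3,4-difluorophenyl in place of 2-fluorophenyl on an amine nitrogen in a ring. Within the data shown here, no measured step bears directly on this change: the only step recorded, from compound 1 to compound 2, exchanges isopropyl for 2-fluorophenyl, whereas the present change keeps a fluorinated phenyl on the same ring nitrogen and only alters its fluorine count and placement. With nothing to suggest a shift, compound 3 is expected to stay close to compound 2, a step of a number 4.2 percentage points higher from compound 2 to compound 3 (within the scatter) that does not go beyond the scatter. Compound 3 is therefore estimated at -5%, with a range from -25% to 15%.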

Compound 3, a percentage reported as activity, at one concentration (the size of the read-out at that concentration, not a potency): -78%
Beside the measured number, compound 3's estimate is 73 percentage points above it; the whole stated range lies above it.
By their numbers in this assay, from the lowest: compound 3; then compound 2; then compound 1.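

In this assay, the group on the ring nitrogen proved far more sensitive than the earlier pair suggested: keeping a fluorinated phenyl there and changing only its fluorine count and placement gave a number 68.8 percentage points lower from compound 2 to compound 3 (beyond the scatter). Measured against the isopropyl group, the 3,4-difluorophenyl group gave a number 85.3 percentage points lower from compound 1 to compound 3 (beyond the scatter), so at this position the fluorine pattern on the phenyl can matter much more than the modest step from isopropyl to 2-fluorophenyl had indicated. Nothing available explains why this change has so large an effect.

The compounds shown change fluorine count and placement together, so they leave open how far each contributes to the step. On these data alone, it also remains open how 3-fluorophenyl, 4-fluorophenyl or unsubstituted phenyl would read in this assay.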